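The compounds below may be only part of what the source reports. "The series", "measured", "known", "first", "only" and "open" are said of these compounds alone.

Three compounds have values so far in an ADME assay on MT4 cells (Homo sapiens) for cytotoxicity, read by spectrophotometry, with a stated time of 5 days; on this read-out lower numbers stand for higher toxicity in this test and higher numbers for lower toxicity in this test
- compound 1 `CCN(CC)CN1C(=O)/C(=N\NC(=S)NOC)c2cc(C)ccc21` gives 573000 nM
- compound 2 `CN(C)CN1C(=O)/C(=N\NC(=S)NO)c2cc(Cl)ccc21` gives 610000 nM
- compound 3 `CONC(=S)N/N=C1\C(=O)N(CN(C)C)c2ccc(Cl)cc21` gives 552000 nM

Compound 3 lies within the scatter of both other compounds, so it holds no distinct place among the three. Compound 4 `CCN(CC)CN1C(=O)/C(=N\NC(=S)NOC)c2cc(Cl)ccc21` departs from compound 3 in one group: diethylamino in place of dimethylamino on a saturated chain carbon bound to an amide-type nitrogen in a ring. Among the compounds with values here, no measured pair isolates this change. Within the data shown here, the only measured step, a 1.1-fold lower number from compound 2 to compound 3 (0.04 log units; within the scatter), is a different change, methyl in place of hydrogen on an oxygen, and it stayed within the scatter. It therefore bears on the new step only indirectly. Compound 3, with dimethylamino, gives 552000 nM in this read-out, and compound 1, which carries diethylamino on a core that differs in one further group, gives 573000 nM in the same test, a gap within the scatter. Neither observation suggests a shift in this assay beyond the scatter, in either direction. The expected step, a 1.0-fold higher number from compound 3 to compound 4 (0.01 log units; within the scatter), is estimated to stay within the scatter. The estimated value of compound 4 is 560000 nM, with a range of 330000 nM to 900000 nM expected.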

Compound 4, half-maximal cytotoxic concentration: 454000 nM
For compound 4 the middle estimate is 1.2-fold (0.09 log units) above the measured one; the range from low to high includes it.
By their numbers in this assay, from the lowest: compounds 4, 3, 1 and 2 (each within the scatter of the next).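

Within the data shown here, compound 4 gives the first measured pair that isolates diethylamino in place of dimethylamino on a saturated chain carbon bound to an amide-type nitrogen in a ring (a 1.2-fold lower number from compound 3 to compound 4 (0.08 log units; within the scatter)) in this assay; this exchange, which takes the group from 3 to 5 heavy atoms, stays within the scatter. It also provides the first pair that isolates chloro in place of methyl on an aromatic carbon (a 1.3-fold lower number from compound 1 to compound 4 (0.10 log units; within the scatter)), and this step too stays within the scatter, so neither site has yet shown a change beyond it in this test. No supporting evidence is available to explain either small step.

The compounds shown leave open whether dipropylamino or another longer chain on the amine at this position would shift the number beyond the scatter. They also leave open whether bromo or methoxy on that aromatic carbon would do so, and whether chloro in place of methyl would give a similar step with dimethylamino on the chain.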